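Fluorine additions on a benzylsulfanyl triazole scaffold

This account rests on a few compounds, and the source may have more. Where it says the series, first, only, none or still open, it means among the compounds named here.

Measured compounds:
compound 1 `COc1cccc(CSc2nnc(-c3ccc4c(c3)OCCO4)n2-c2ccccc2)c1`, > 100000 nM
compound 2 `Fc1ccc(CSc2nnc(-c3ccc4c(c3)OCCO4)n2-c2ccccc2)cc1`, 46900 nM

In a functional assay on HeLa cells (Homo sapiens) for antiproliferative activity, read by MTT assay, with a stated time of 24 h (on this read-out higher numbers stand for weaker inhibition and lower numbers for stronger inhibition), compound 1 gives only a limit, > 100000 nM. Compound 2 gives 46900 nM, the only number shown in this assay. Among the measured compounds shown here, the step of an at least 2.1-fold lower number from compound 1 to compound 2 (0.32 log units; beyond the scatter) is the sole measured step, bounded by the limit of > 100000 nM in this assay, at which 1 of the 2 values shown sits. Compound 3 `Fc1ccc(CSc2nnc(-c3ccc4c(c3)OCCO4)n2-c2ccccc2)c(F)c1` differs from compound 2 by fluoro in place of hydrogen on an aromatic carbon. That difference is not the one measured, so it gives little guidance. Compound 3 is expected to show a small step, a 1.5-fold lower number from compound 2 to compound 3 (0.17 log units; within the scatter), near the scatter. The estimated value of compound 3 is 32000 nM, between 10000 nM and 100000 nM.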

Compound 3, half-maximal inhibitory concentration: 18600 nM
The estimate for compound 3 lay 1.7-fold (0.24 log units) above the measured number, and the stated range covers the measured number.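

In this assay, among the compounds shown here, fluoro in place of hydrogen on the aromatic carbon ortho to a large group gives a 2.5-fold lower number from compound 2 to compound 3 (0.40 log units; beyond the scatter), the first step beyond the scatter that rests on two actual numbers. Replacing 3-methoxyphenyl with 2,4-difluorophenyl gives an at least 5.3-fold lower number from compound 1 to compound 3 (0.73 log units; beyond the scatter). That step is only a bound, as compound 1 gives a limit and not a number: the limit of > 100000 nM in this assay, at which 1 of the 3 values shown sits.

From the compounds shown here alone, it remains open whether fluoro at this position would give a similar step without the 4-fluoro group. Going by these compounds, it is also open whether chlorine, a methoxy group or an amine there would behave like fluoro.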